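Series notes: from compound 2 to compound 3

The compounds below may be only part of what the source reports. "The series", "measured", "known", "first", "only" and "open" are said of these compounds alone.

In a functional assay on COLO 205 cells (Homo sapiens) for inhibition, read by sulforhodamine B assay, with a stated time of 48 h, tested at 50 uM (a higher number here means more inhibition of growth at the concentration tested, a lower number less inhibition of growth), compound 1 `COc1cc(/C=C/C(=O)/C=C/c2ccco2)ccc1OCc1cn(CCCOc2cc(=O)oc3ccccc23)nn1` gives 59% and compound 2 `COc1ccc(/C=C/C(=O)/C=C/c2ccc(OCc3cn(CCCOc4cc(=O)oc5ccccc45)nn3)c(OC)c2)cc1OC` gives 65%, so compound 2 stands level with compound 1 within the scatter. Compound 3 `COc1ccc(/C=C/C(=O)/C=C/c2ccc(OCc3cn(CCCOc4cc(=O)oc5ccccc45)nn3)c(OC)c2)cc1` differs from compound 2 in one place: hydrogen in place of methoxy on an aromatic carbon. Hydrogen stands in place of methoxy on an aromatic carbon, turning 3,4-dimethoxyphenyl into 4-methoxyphenyl. Among the compounds with values here, the only measured step, a number 6 percentage points higher from compound 1 to compound 2 (within the scatter), exchanged furan-2-yl for 3,4-dimethoxyphenyl, a different change on the same side of the molecule. No step beyond the scatter is therefore expected in this assay. The estimated step is a number 3 percentage points lower from compound 2 to compound 3 (within the scatter). Compound 3 is expected at 62%, with an estimated range of 48% to 75%.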

Compound 3, percent growth inhibition at one concentration: 53%
Compound 3: middle estimate off by 9 percentage points, on the high side; the measured number falls inside the stated range.
By their numbers in this assay, from the lowest: compounds 3, 1 and 2 (each within the scatter of the next, the first and the last beyond it).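

In this assay, within the data shown here, hydrogen in place of methoxy on the aromatic carbon ortho to a methoxy group gives a number 12 percentage points lower from compound 2 to compound 3 (beyond the scatter) and is the first step of this size, so 3,4-dimethoxyphenyl and 4-methoxyphenyl are not interchangeable here. Set against furan-2-yl, 4-methoxyphenyl gives a number 6 percentage points lower from compound 1 to compound 3 (within the scatter) and leaves compound 1 unseparated from either phenyl compound. Nothing on hand accounts for the loss.

Open, as far as these compounds go, is how a hydroxy group, a fluorine or an amine on that aromatic carbon would compare with methoxy and hydrogen. Also open, from the compounds shown here alone, is whether the step holds with furan-2-yl replaced by other rings.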